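Working notes on the aryl ether series

This account rests on a few compounds, and the source may have more. Where it says the series, first, only, none or still open, it means among the compounds named here.

compound 1, `O=c1oc2cc(OCCCOc3ccc(Cl)cc3)ccc2s1`: 77.9% in a functional assay on the whole organism (strain albino) for inhibition, with Mus musculus as the target, with stated times of 30 min, 20 min and 5 min, at a dose of 25 mg/kg by the intraperitoneal route; a higher number here means more inhibition at the dose given (going by the name of the read-out), a lower number less inhibition
compound 2, `Cc1ccc(OCCCOc2ccc3sc(=O)oc3c2)cc1`: 77.3% in this assay

Compound 2 stands lowest of the two numbers, with compound 1 nearest by a number 0.6 percentage points lower from compound 1 to compound 2 (within the scatter); within the scatter, so no order between the two is claimed. Compound 3, `O=c1oc2cc(OCCCOc3ccc([N+](=O)[O-])cc3)ccc2s1`, is not yet measured. It differs from compound 2 by nitro in place of methyl on an aromatic carbon. Within the data shown here, the only measured step, a number 0.6 percentage points lower from compound 1 to compound 2 (within the scatter), concerns methyl for chloro and not nitro, so no step bears directly on this change; it shows only that one exchange at this carbon left the read-out flat. Compound 3 is therefore expected to move by a number 3.3 percentage points lower from compound 2 to compound 3 (within the scatter), not beyond the scatter. Compound 3 is estimated at 74%, between 52% and 90%.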

Compound 3, a percentage reported as inhibition, in the whole organism at one dose (the size of the read-out at that dose, not a potency): 80%
Compound 3: the middle estimate sits 6 percentage points below what was measured; the range from low to high includes it.
By their numbers in this assay, from the lowest: compounds 2, 1 and 3 (each within the scatter of the next).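

Nitro, with 3 heavy atoms and 2 hydrogen-bond acceptors, now joins methyl and chloro on this aromatic carbon, para to a large group, and the read-out in this assay again stays within the scatter (a number 2.7 percentage points higher from compound 2 to compound 3 (within the scatter); a number 2.1 percentage points higher from compound 1 to compound 3 (within the scatter)). The earlier pair showed one exchange at this carbon; the three compounds now show that these two further exchanges also give no order among methyl, chloro and nitro.

Still open, going by these compounds, is whether an amine or a carboxylic acid on this carbon would stay within the scatter, and whether a longer chain to the shared core would do the same. Nothing at hand explains the read-out at this position.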